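A Methylphenyl in Place of a Fluorophenyl on an Aromatic Nitrogen

The source may report more compounds than this note shows. Statements on the series, on what has been measured and on what is new or still open speak of the compounds shown alone.

Within the data shown here, compound 3 `Cc1cc(=O)n(-c2cccc(F)c2)nc1C(=O)Nc1ccc(Oc2ncnc3c2ccn3C)cc1` gives 23400 nM in a functional assay on A549 cells (Homo sapiens) for cytotoxicity, read by MTT assay, with a stated time of 72 h (on this read-out lower numbers stand for stronger inhibition and higher numbers for weaker inhibition), the second highest of the three numbers so far. Compound 2 `Cc1cc(=O)n(-c2ccc(Br)cc2F)nc1C(=O)Nc1ccc(Oc2ncnc3c2ccn3C)cc1` gives 47300 nM, while compound 1 `Cc1ccc(-n2nc(C(=O)Nc3ccc(Oc4ncnc5[nH]ccc45)cc3)c(C)cc2=O)cc1`, which carries a different core, gives 6400 nM. Among the measured compounds shown here, the only measured step at the same aromatic nitrogen, a 2.0-fold lower number from compound 2 to compound 3 (0.31 log units; beyond the scatter), shows that exchanging this aryl group moved the number only modestly. Compound 4 `Cc1ccc(-n2nc(C(=O)Nc3ccc(Oc4ncnc5c4ccn5C)cc3)c(C)cc2=O)cc1` differs from compound 3 in that (4-methylphenyl in place of 3-fluorophenyl on an aromatic nitrogen). Compound 1 carries the same 4-methylphenyl and shows a lower number than compound 3, but it also differs in its core, so it is not a clean guide. Compound 4 is therefore expected to stay close to compound 3, with a 1.8-fold lower number from compound 3 to compound 4 (0.26 log units; within the scatter) as the expected shift. The estimate for compound 4 is 13000 nM, within 4000 nM to 40000 nM.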

Compound 4, half-maximal inhibitory concentration: > 60000 nM
Compound 4: only a limit was reported; the forecaster's own chance of this, stated with the estimate: 10%; middle value at least 4.6-fold (0.66 log units) away from the limit.
By their numbers in this assay, from the lowest: compound 1; then compound 3; then compound 2. At a limit, above all of these: compound 4.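

For compound 4 only a limit was obtained, not a number: the limit of > 60000 nM in this assay, at which 1 of the 4 values shown sits. Even so, the aryl group on this aromatic nitrogen proves able to move the number, as 4-methylphenyl in place of 3-fluorophenyl gives an at least 2.5-fold higher number from compound 3 to compound 4 (0.40 log units; beyond the scatter), while with 4-methylphenyl held fixed, methyl in place of hydrogen on the core's aromatic nitrogen gives an at least 9.3-fold higher number from compound 1 to compound 4 (0.97 log units; beyond the scatter). By contrast, 4-methylphenyl in place of 4-bromo-2-fluorophenyl on this aromatic nitrogen gives an at least 1.2-fold higher number from compound 2 to compound 4 (0.10 log units; that floor lies within the scatter) and so cannot be read.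

As far as these compounds go, how far compound 4 lies past its limit stays open, so both readable steps are only floors. Also open, from the compounds shown here alone, is how an aminophenyl or a carboxyphenyl group on this aromatic nitrogen would behave.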